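A few compounds are considered here, and "the series" means these few. Any claim that something is new, unique, unknown or untested is made for them only; others in the source may bear on it.

In a functional assay on T47D cells (Homo sapiens) for inhibition, read by MTT assay, with a stated time of 48 h (a lower number here means a stronger inhibitor, a higher number a weaker inhibitor), compound 1 `CCOC(=O)c1c(N)sc(/N=C/c2ccc([N+](=O)[O-])o2)c1C(=O)OCC` gives 16000 nM. Two compounds sharing its core have also been measured: compound 2 `CCOC(=O)c1c(N)sc(/N=C/c2ccc(N(C)C)cc2)c1C(=O)OCC` gives 16700 nM, and compound 3 `CCOC(=O)c1c(N)sc(/N=C/c2ccncc2)c1C(=O)OCC` gives 8600 nM. Compound 1 has no distinct place among these three, as its steps to both others lie within the scatter: a 1.0-fold higher number from compound 1 to compound 2 (0.02 log units; within the scatter) and a 1.9-fold lower number from compound 1 to compound 3 (0.27 log units; within the scatter). The remaining step, a 1.9-fold lower number from compound 2 to compound 3 (0.29 log units; within the scatter), also lies within the scatter.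

Compound 4 `CCOC(=O)c1c(N)sc(/N=C/c2ccc(C)cc2)c1C(=O)OCC` has yet to be measured. It carries 4-methylphenyl in place of 5-nitrofuran-2-yl on a carbon with a double bond to nitrogen. Among the compounds with values here, the nearest precedent is the step to compound 2, which also replaces 5-nitrofuran-2-yl with a substituted phenyl and gave a 1.0-fold higher number from compound 1 to compound 2 (0.02 log units; within the scatter). The step to compound 3 shows that a different ring there also stayed within the scatter. No step beyond the scatter is therefore expected in this assay, and the estimated result is a 1.1-fold lower number from compound 1 to compound 4 (0.06 log units; within the scatter). Compound 4 is expected at 14000 nM, within an estimated range of 7000 nM to 28000 nM.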

Compound 4, half-maximal inhibitory concentration: 37200 nM
Compound 4: middle estimate off by 2.7-fold (0.42 log units), on the low side, outside the stated range (above it).
By their numbers in this assay, from the lowest: compounds 3, 1 and 2 (each within the scatter of the next); then compound 4.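

In this assay, the group on the carbon with a double bond to nitrogen now makes a difference beyond the scatter: 4-methylphenyl gives a 2.3-fold higher number from compound 1 to compound 4 (0.37 log units; beyond the scatter) and a 4.3-fold higher number from compound 3 to compound 4 (0.64 log units; beyond the scatter), so compound 4 is the weakest of the four, though both steps are modest. The change on the phenyl alone, methyl in place of dimethylamino on an aromatic carbon, gives a 2.2-fold higher number from compound 2 to compound 4 (0.35 log units; beyond the scatter), showing that the substituent on the phenyl matters even though compound 2 lay within the scatter of compound 1 and compound 3. Nothing available explains this shift.

As far as these compounds go, it remains open whether a methoxy group, a chlorine atom or a carboxylic acid in place of that methyl would read like compound 4 or like compound 2. An unsubstituted phenyl would show whether the methyl or the dimethylamino group sets this gap.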